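The source may hold more compounds than are shown below. What is called first, only, known or untested is meant among the compounds shown, and "the series" means these compounds.

Measured compounds:
compound 1, `Fc1ccc(Nc2cc(Nc3ccc(Oc4ccncc4-c4cccnc4)c(F)c3)ncn2)cc1`, 14100 nM
compound 2, `Cn1c(=O)c(C(=O)Nc2ccc(Oc3ccncc3-c3cccnc3)c(F)c2)nn(-c2ccccc2F)c1=O`, 6760 nM

In a functional assay on MDA-MB-231 cells (Homo sapiens) for cytotoxicity, read by MTT assay, with a stated time of 72 h (a lower number here means a stronger inhibitor, a higher number a weaker inhibitor), compound 1 gives 14100 nM. In this assay compound 2 gives 6760 nM, the lower of the two numbers; the gap from compound 1 to compound 2 lies beyond the usual scatter of repeated measurements, so compound 2 stands as the stronger of the two measured compounds. Compound 1 and compound 2 differ in more than one place, so nothing can be said about which part of that difference carries the gap.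

Compound 3 `Cn1c(=O)c(C(=O)Nc2ccc(Oc3ccncc3-c3cccnc3)c(F)c2)nn(-c2cccc(C(F)(F)F)c2)c1=O` differs from compound 2 in one place only: 3-(trifluoromethyl)phenyl in place of 2-fluorophenyl on an aromatic nitrogen. Among the compounds with values here, no measured pair shows this change, so its effect on this assay is unknown. Within the data shown here, the author expects a step from compound 2 to compound 3 of a 1.2-fold lower number from compound 2 to compound 3 (0.09 log units; within the scatter), small and not clearly beyond the scatter, because the only anchor is compound 2 with 6760 nM. For compound 3 the estimate in this assay is 5500 nM, with a range from 1500 nM to 18000 nM.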

Compound 3, half-maximal inhibitory concentration: 3980 nM
Estimate against measurement, compound 3: 1.4-fold (0.14 log units) above; the range from low to high includes it.
By their numbers in this assay, from the lowest: compounds 3 and 2 (each within the scatter of the next); then compound 1.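

Within the data shown here, the step from 2-fluorophenyl to 3-(trifluoromethyl)phenyl on the aromatic nitrogen is the first change in one place only that can be read, and in this assay it gives a 1.7-fold lower number from compound 2 to compound 3 (0.23 log units; within the scatter) and stays within the usual scatter. The two aryl groups therefore cannot be told apart here, even though the entering group carries 10 heavy atoms against 7 and has its fluorine on a trifluoromethyl group rather than directly on the six-membered ring. Nothing measured bears on what lies behind this result.

From the compounds shown here alone, a single pair covers only these two fluorine-bearing aryl groups, so it remains open whether a phenyl ring carrying an amine or a carboxylic acid, or a longer alkyl chain in place of the aryl ring, would give a number beyond the scatter from that of compound 2. Among these compounds, it also remains open whether the same exchange would behave alike on a different core, such as the one in compound 1.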